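Arylpiperazine series: chloro to fluoro on the aryl ring

A few compounds are considered here, and "the series" means these few. Any claim that something is new, unique, unknown or untested is made for them only; others in the source may bear on it.

Measured compounds:
- compound 1 `CCC1(CCCCN2CCN(c3cccc(Cl)c3)CC2)C(=O)Nc2ccccc21`: 31 nM
- compound 2 `CCC1(CCCCN2CCN(c3ccc(Cl)cc3)CC2)C(=O)Nc2ccccc21`: 93 nM

Two compounds sharing one core have been run in an assay on membranes from frontal cortex for displacement of a labelled ligand from Adrenergic receptor alpha-1 (Rattus norvegicus), read by scintillation counting, with a stated time of 45 min (on this read-out lower numbers stand for stronger inhibition and higher numbers for weaker inhibition), where compound 1 gives 31 nM and compound 2 gives 93 nM. Within the data shown here, the single measured step is a 3.0-fold higher number from compound 1 to compound 2 (0.48 log units; beyond the scatter). Among the measured compounds shown here, compound 2 therefore carries the highest number of the two, with compound 1 as its only neighbour.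

Compound 3 `CCC1(CCCCN2CCN(c3ccc(F)cc3)CC2)C(=O)Nc2ccccc21` is not yet measured. Relative to compound 2 the change is fluoro in place of chloro on an aromatic carbon. For the measured compounds named here, no measured step in this set exchanges one halogen for another; the only step available, a 3.0-fold higher number from compound 1 to compound 2 (0.48 log units; beyond the scatter), moves the same chloro between two positions and so bears on the new change only indirectly, showing that the aryl substituent does influence the number in this assay at a modest scale. For fluoro in place of chloro at the same position, a step of about the same size or smaller is expected, with no firm direction; a slight rise in the number is taken as the central guess. For compound 3 the expected step is a 1.3-fold higher number from compound 2 to compound 3 (0.11 log units; within the scatter), giving an estimate of 120 nM, within a range of 40 nM to 400 nM.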

Compound 3, inhibition constant: 39 nM
Compound 3: the middle estimate sits 3.1-fold (0.49 log units) above what was measured, outside the stated range (below it).
By their numbers in this assay, from the lowest: compounds 1 and 3 (each within the scatter of the next); then compound 2.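

In this assay, the halogen itself matters at the position para to a large group: fluoro in place of chloro gives a 2.4-fold lower number from compound 2 to compound 3 (0.38 log units; beyond the scatter), whereas the earlier step showed only that moving chloro could shift the number. The 4-fluorophenyl compound also cannot be told apart from the 3-chlorophenyl compound, with a 1.3-fold higher number from compound 1 to compound 3 (0.10 log units; within the scatter), so the higher number of compound 2 belongs to the 4-chlorophenyl group and not to substitution at that position as such. No measurement at hand offers an explanation for this halogen difference.

The compounds shown leave open whether the number at this position follows the halogen series on to bromo, and how a hydrogen or a methoxy group there would compare with fluoro and chloro. They also leave open how fluoro would read where chloro sits in compound 1, and whether the difference between the 4-chlorophenyl and 4-fluorophenyl groups would persist with a shorter chain between the shared core and the amine ring.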